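Phenyl Loss in Two Places of One Antagonist Series

The source may report more compounds than this note shows. Statements on the series, on what has been measured and on what is new or still open speak of the compounds shown alone.

Compound 1 `CN(C)CC#CCCC1SCCCS1`, compound 2 `CN(CC#CCCC1SCCCS1)Cc1ccccc1` and compound 3 `CCN(CC)CC#CCCC1(C(c2ccccc2)c2ccccc2)SCCCS1` were examined in a functional assay for antagonist activity, with Cavia porcellus as the target; a lower number here means a stronger inhibitor, a higher number a weaker inhibitor. For compound 1 the assay reports only a limit, > 10000000 nM. Compound 2 gives 8020 nM, and compound 3 gives 500 nM, the lowest of the two numbers. The change hydrogen in place of phenyl on a saturated chain carbon bound to an amine nitrogen brought an at least 1200-fold higher number from compound 2 to compound 1 (3.09 log units; beyond the scatter), and compound 1 sits at the limit of > 10000000 nM in this assay, at which 1 of the 3 values shown sits. How the core of compound 3 differs from that of compound 2 is not broken down here. Within the data shown here, compound 4 `CCN(CC)CC#CCCC1(Cc2ccccc2)SCCCS1` has no measurement yet; it arises from compound 3 by hydrogen in place of phenyl on a saturated chain carbon bound to an aromatic carbon and a saturated ring carbon, the same kind of change, though its place is a saturated chain carbon bound to an aromatic carbon and a saturated ring carbon rather than one bound to an amine nitrogen. Because of the large step of an at least 1200-fold higher number from compound 2 to compound 1 (3.09 log units; beyond the scatter), compound 4 is expected to be weaker, by an estimated 10-fold higher number from compound 3 to compound 4 (1.00 log units; beyond the scatter). The estimate for compound 4 in this assay is 5000 nM, between 1000 nM and 50000 nM.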

Compound 4, antagonist equilibrium constant: 1960 nM
The estimate for compound 4 lay 2.6-fold (0.41 log units) above the measured number, and the stated range covers the measured number.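

In this assay, hydrogen in place of phenyl on a saturated chain carbon bound to an aromatic carbon and a saturated ring carbon gave a 3.9-fold higher number from compound 3 to compound 4 (0.59 log units; beyond the scatter), and the two phenyl losses differ clearly in size: the same change on two cores in this assay, an at least 1200-fold higher number (3.09 log units; beyond the scatter) from compound 2 to compound 1 and a 3.9-fold higher number (0.59 log units; beyond the scatter) from compound 3 to compound 4, at least 310-fold (2.50 log units) apart, beyond the scatter of two such steps The direction of the change carried from one core to the other while its size did not, and since the two steps differ in place as well as in core, they do not show which of the two sets the size. Compound 1 stands only at a limit, so the earlier step has no exact size: the limit of > 10000000 nM in this assay, at which 1 of the 4 values shown sits.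

As far as these compounds go, it remains open whether a cyclohexyl or a pyridyl in place of the lost phenyl would hold the number of compound 3. Also open, from the compounds shown here alone, is how the same change behaves with a piperidine in place of the amine of compound 3.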